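A Fluorine Added to the Acid with the Lower Number

The compounds below may be only part of what the source reports. "The series", "measured", "known", "first", "only" and "open" are said of these compounds alone.

Compound 2 `CN1CCN(c2ccc(Nc3nc(-c4cccc(NC(=O)c5ccccc5)c4)sc3C(=O)O)cc2)CC1` stands lowest of the two numbers at hand: in a functional assay on Ramos cells (Homo sapiens) for antiproliferative activity, read by CCK-8 assay, with a stated time of 72 h, tested at 40 uM (on this read-out lower numbers stand for less inhibition and higher numbers for more inhibition at the one concentration tested (going by the name of the read-out)), compound 2 gives 26.3%, while compound 1 `CCOC(=O)c1sc(-c2cccc(NC(=O)c3cccc(F)c3)c2)nc1Nc1ccc(N2CCN(C)CC2)cc1` gives 85.2%. These two compounds differ in more than one place, so what any single change contributes is not shown by them. Compound 3 `CN1CCN(c2ccc(Nc3nc(-c4cccc(NC(=O)c5cccc(F)c5)c4)sc3C(=O)O)cc2)CC1` differs from compound 2 only by fluoro in place of hydrogen on an aromatic carbon. With no measured single change to lean on, a modest rise is expected, a number 9.7 percentage points higher from compound 2 to compound 3 (within the scatter). Compound 3 is therefore estimated to give 36%, within a range from 15% to 60%.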

Compound 3, a percentage reported as inhibition, at one concentration (the size of the read-out at that concentration, not a potency): 82.7%
Estimate against measurement, compound 3: 46.7 percentage points below; the whole stated range lies below it.
By their numbers in this assay, from the lowest: compound 2; then compounds 3 and 1 (each within the scatter of the next).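

In this assay, the change from benzamido to ((3-fluorophenyl)carbonyl)amino proves large for a single atom: a number 56.4 percentage points higher from compound 2 to compound 3 (beyond the scatter). With fluoro present, hydrogen in place of ethyl on an oxygen next to a carbonyl group makes no clear difference, a number 2.5 percentage points lower from compound 1 to compound 3 (within the scatter), so the carboxylic acid and the ethyl ester cannot be told apart here. Nothing at hand explains the size of the fluoro step.

As far as these compounds go, whether chloro or methoxy at the same place would give a similar rise remains open. So does how the ethyl ester would read with a plain benzamido group.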